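Notes on two measured compounds and one to come

This account rests on a few compounds, and the source may have more. Where it says the series, first, only, none or still open, it means among the compounds named here.

compound 1 `Cc1cccc(N(C)c2cc(Nc3cccc(C(=O)N(CC(C)C)CC(C)C)c3)ncn2)c1`: 9%
compound 2 `Clc1ccc2sc(CN3CCN(c4ncnc5c4CN(Cc4ccccc4)CC5)CC3)cc2c1`: 13%

In an assay on isolated protein for inhibition of high affinity nerve growth factor receptor (Homo sapiens), read by HTRF, tested at 10 uM (on this read-out higher numbers stand for more inhibition at the one concentration tested (going by the name of the read-out) and lower numbers for less inhibition), compound 1 gives 9% and compound 2 gives 13%; the two numbers lie within the scatter of each other, so neither stands apart. Compound 3 `O=C(CN1CCN(c2ncnc3c2CN(Cc2ccccc2)CC3)CC1)Nc1cc(F)ccc1F` has not been measured. It differs from compound 2 thus: (2,5-difluorophenyl)carbamoyl in place of 5-chloro-1-benzothiophen-2-yl on a saturated chain carbon bound to an amine nitrogen in a ring. Among the compounds with values here, no measured pair shows what this change does in this assay, so no step beyond the scatter is expected in either direction. For compound 3 the expected value in this assay is 10%, with a range from 0% to 25%. Expected is a step of a number 3 percentage points lower from compound 2 to compound 3 (within the scatter), none beyond the scatter.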

Compound 3, a percentage reported as inhibition, at one concentration (the size of the read-out at that concentration, not a potency): 10%
Beside the measured number, compound 3's estimate shows no gap at the digits printed; the measured number falls inside the stated range.
By their numbers in this assay, from the lowest: compounds 1, 3 and 2 (each within the scatter of the next).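

In this assay, (2,5-difluorophenyl)carbamoyl in place of 5-chloro-1-benzothiophen-2-yl on a saturated chain carbon bound to an amine nitrogen in a ring gives a number 3 percentage points lower from compound 2 to compound 3 (within the scatter) as the step at this position. The position therefore takes this exchange of two aromatic rings for one, with a hydrogen-bond donor entering, without a step beyond the scatter. No measured property bears on this result.

On these data alone, whether an amine or a carboxylic acid at this position would give a step beyond the scatter remains open. The same holds for a longer chain between the ring nitrogen and the (2,5-difluorophenyl)carbamoyl group.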